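Removing a Methyl from an Ether Oxygen: Effect on Lipophilicity

This account rests on a few compounds, and the source may have more. Where it says the series, first, only, none or still open, it means among the compounds named here.

Compound 1 has the structure `COC(CCC(C)C/C=C/C(C)=C/C(=O)OC(C)C)C(C)(C)OC`. In a physicochemical assay for lipophilicity (a higher number here means a more lipophilic compound, a lower number a more polar compound), compound 1 gives 4.75. Compound 2, with the structure `COC(C)(C)C(O)CCC(C)C/C=C/C(C)=C/C(=O)OC(C)C`, differs from compound 1 in one spot: hydrogen in place of methyl on an oxygen on a saturated carbon. In this assay compound 2 gives 3.86, so the step is a number 0.89 log units lower from compound 1 to compound 2 (beyond the scatter). Compound 3, with the structure `CCSC(=O)/C=C(C)/C=C/CC(C)CCCC(C)(C)OC`, rests on a different core; the difference between the two cores is not broken down here. In this assay compound 3 gives 6.78, the highest number among the three measured compounds. Compound 4, with the structure `CCSC(=O)/C=C(C)/C=C/CC(C)CCCC(C)(C)O`, has not yet been measured. It differs from compound 3 in the same way that compound 2 differs from compound 1: hydrogen in place of methyl on an oxygen on a saturated carbon. The place of the change reads the same in both pairs, so this is the same change seen a second time. Because the same change earlier gave a number 0.89 log units lower from compound 1 to compound 2 (beyond the scatter), the expected step is a number 0.88 log units lower from compound 3 to compound 4 (beyond the scatter). For compound 4 a value of about 5.9 is estimated, expected to fall between 5.4 and 6.4. Within the data shown here, with only one earlier example to rest on, this estimate stays uncertain.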

Compound 4, partition coefficient: 5.89
Compound 4: the middle estimate sits 0.01 log units above what was measured; the range from low to high includes it.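

In this assay, going from methoxy to hydroxy on the core of compound 3 gives a number 0.89 log units lower from compound 3 to compound 4 (beyond the scatter), while the same change on the core of compound 1 gave a number 0.89 log units lower from compound 1 to compound 2 (beyond the scatter), so the step carried over from one core to the other at the same size. Among these compounds, this rests on only two pairs on two cores, so it shows that the change transferred here but does not show that it would do so on any further core. Nothing given here explains why the two steps match, and the result stands as an observation without a known cause.

The compounds shown leave open how other groups at this place would compare, such as an amine or a carboxylic acid in place of the hydroxy, or ethoxy, with its longer chain, in place of the methoxy. They also leave open whether any such replacement would give steps that match across the two cores as closely as this one does.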